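Bromo to furan-3-yl on the shared core

The source may report more compounds than this note shows. Statements on the series, on what has been measured and on what is new or still open speak of the compounds shown alone.

Compound 1 (`Nc1ncc(-c2ccnc3ccccc23)c(C2CC2)n1`): > 100000 nM (a limit)
Compound 2 (`Nc1ncc(-c2ccncc2Br)c(C2CC2)n1`): 75000 nM

Going by the values given here, compound 2 at 75000 nM in a functional assay on CUTLL1 cells (Homo sapiens) for inhibition, read by resazurin assay, with a stated time of 48 h, in the presence of a further agent that is not named here (on this read-out higher numbers stand for an effect only at larger amounts of compound and lower numbers for an effect already at smaller amounts), is the only number so far. For compound 1 the result > 100000 nM is a limit of the assay and not a number. Compound 3 (`Nc1ncc(-c2ccncc2-c2ccoc2)c(C2CC2)n1`) follows from compound 2 by furan-3-yl in place of bromo on an aromatic carbon with furan-3-yl in place of bromo on an aromatic carbon. Among the compounds with values here, no measured step yet gives a size for such a change. The expected step is a 3.0-fold lower number from compound 2 to compound 3 (0.48 log units; beyond the scatter) and it is expected to run towards effect at smaller amounts. In this assay compound 3 is estimated at 25000 nM within an expected range of 4000 nM to 100000 nM for now.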

Compound 3, half-maximal effective concentration: 28000 nM
The estimate for compound 3 lay 1.1-fold (0.05 log units) below the measured number; measured number inside the range.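

Furan-3-yl in place of bromo on this aromatic carbon, ortho to a large group, gives a 2.7-fold lower number from compound 2 to compound 3 (0.43 log units; beyond the scatter) in this assay. Going by these compounds alone, the position therefore accepts a five-membered aromatic ring in place of a bromine with no loss, and this is the first size for a change at this place. Compound 1 stands at a limit, so no step to it can be read: the limit of > 100000 nM in this assay, at which 1 of the 3 values shown sits.

From the compounds shown here alone, whether the shift comes from the ring itself or from its oxygen stays open. So does the effect of a phenyl ring, an amine or a carboxylic acid at this place.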